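Chalcone analogues: a difluorophenyl variant on the carbonyl carbon

The source may hold more compounds than are shown below. What is called first, only, known or untested is meant among the compounds shown, and "the series" means these compounds.

Compounds measured so far:
compound 1 `COc1cc(-c2cc(/C=C/C(=O)c3ccc(Cl)c(Cl)c3)[nH]n2)cc(OC)c1OC` – 98% in a functional assay on SK-MEL-5 cells (Homo sapiens) for cytotoxicity, read by sulforhodamine B assay, with a stated time of 48 h, tested at 0.01 uM; a higher number here means a weaker effect of the compound at the concentration tested, a lower number a stronger effect
compound 2 `COc1ccc(C(=O)/C=C/c2cc(-c3cc(OC)c(OC)c(OC)c3)n[nH]2)cc1` – 100% in this assay

Compound 2 gives the highest of the two numbers in this assay, with compound 1 the nearest, within the scatter. Compound 3 `COc1cc(-c2cc(/C=C/C(=O)c3ccc(F)c(F)c3)[nH]n2)cc(OC)c1OC` carries 3,4-difluorophenyl in place of 4-methoxyphenyl on a carbonyl carbon. Among the compounds with values here, the one step that bears on this place, a number 2 percentage points higher from compound 1 to compound 2 (within the scatter), was within the scatter, so no step beyond the scatter is expected here either. The expected step is a number 1 percentage points lower from compound 2 to compound 3 (within the scatter). Compound 3 is therefore estimated at 99%, with a range from 89% to 107%.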

Compound 3, a percentage reported as activity, at one concentration (the size of the read-out at that concentration, not a potency): 98%
Beside the measured number, compound 3's estimate is 1 percentage points above it, within the range that was stated.
By their numbers in this assay, from the lowest: compounds 1, 3 and 2 (each within the scatter of the next).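

In this assay the place on the carbonyl carbon has now taken 3,4-difluorophenyl, with a number 2 percentage points lower from compound 2 to compound 3 (within the scatter), and exchanging 3,4-dichlorophenyl for it gives no change at the digits printed from compound 1 to compound 3 (within the scatter). Across compounds 1, 2 and 3, then, neither a second halogen-bearing phenyl nor the 4-methoxyphenyl group separates from the others at this single concentration. Nothing available accounts for this flat result. Still open, on these data alone, is whether an aminophenyl or carboxyphenyl group at this place would move the number beyond the scatter, and whether these three compounds would separate at another concentration.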